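The source may hold more compounds than are shown below. What is called first, only, known or untested is meant among the compounds shown, and "the series" means these compounds.

Compound 1 `C[C@@H](C(=O)NC1CCCCC1)[C@H]1CC[C@@H](c2ccnc3ccc(F)cc32)CC1`: in an assay on tissue (HeLa cells) for inhibition of Indoleamine 2,3-dioxygenase 1 (Homo sapiens), with stated times of 2 h and 18 h (a higher number here means a weaker inhibitor, a lower number a stronger inhibitor), compound 1 gives 18 nM.
Compound 2 `C[C@@H](NS(=O)(=O)c1ccc(Cl)cc1)[C@H]1CC[C@@H](c2ccnc3ccc(F)cc32)CC1`: in this assay compound 2 reaches only the assay limit > 1000 nM.
Compound 3 `C[C@@H](NC(=O)c1ccccc1Cl)[C@H]1CC[C@@H](c2ccnc3ccc(F)cc32)CC1`: in this assay compound 3 gives 12 nM.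

Compound 3 has the lowest number of the two measured; compound 1 sits within the scatter of it. Compound 4 `C[C@@H](NC(=O)C1CCCCC1)[C@H]1CC[C@@H](c2ccnc3ccc(F)cc32)CC1` differs from compound 3 by cyclohexyl in place of 2-chlorophenyl on a carbonyl carbon. Within the data shown here, the one measured step, an at least 83-fold lower number from compound 2 to compound 3 (1.92 log units; beyond the scatter), swapped a sulfonyl for a carbonyl and so does not bear on this exchange. Compound 1 shows that a cyclohexyl amide is accepted, so no step beyond the scatter is expected. Compound 4 is therefore expected near compound 3, at 20 nM, range 8 nM to 60 nM, a step of a 1.7-fold higher number from compound 3 to compound 4 (0.22 log units; within the scatter).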

Compound 4, half-maximal inhibitory concentration: 12 nM
Beside the measured number, compound 4's estimate is 1.7-fold (0.22 log units) above it, and the stated range covers the measured number.
By their numbers in this assay, from the lowest: compounds 3, 4 and 1 (each within the scatter of the next). At a limit, above all of these: compound 2.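

On this carbonyl carbon a non-aromatic ring serves as well as an aromatic one, and the chlorine is not needed: there is no change at the digits printed from compound 3 to compound 4 (within the scatter). Turning the amide around changes little either, with a 1.5-fold lower number from compound 1 to compound 4 (0.18 log units; within the scatter). The carbonyl link again stands far from the sulfonyl one, with an at least 83-fold lower number from compound 2 to compound 4 (1.92 log units; beyond the scatter), a step that rests on a limit: the limit of > 1000 nM in this assay, at which 1 of the 4 values shown sits.

On these data alone, whether a methyl group or a ring carrying an amine or a carboxylic acid is accepted on this carbonyl carbon stays open. Also open, as far as these compounds go, is how a (4-chlorophenyl)carbonyl group on that amine nitrogen would compare.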